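The compounds below may be only part of what the source reports. "The series", "measured", "known", "first", "only" and "open" are said of these compounds alone.

In a functional assay on HCT-116 cells (Homo sapiens) for antiproliferative activity (a higher number here means a weaker inhibitor, a lower number a stronger inhibitor), three compounds share one core and differ only in the group on an aromatic nitrogen. Compound 1 `O=C(CCCCCCC(=O)Nc1ccc(Nc2nc(-c3cn[nH]c3)c3cc[nH]c3n2)cc1)NO`, with hydrogen there, gives 14400 nM. Compound 2 `CCCn1cc(-c2nc(Nc3ccc(NC(=O)CCCCCCC(=O)NO)cc3)nc3[nH]ccc23)cn1`, with propyl, gives 6500 nM, and compound 3 `C=CCCn1cc(-c2nc(Nc3ccc(NC(=O)CCCCCCC(=O)NO)cc3)nc3[nH]ccc23)cn1`, with but-3-en-1-yl, gives 4100 nM. Compound 3 thus stands clear of compound 1 but cannot be separated from compound 2.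

Compound 4 `COCCn1cc(-c2nc(Nc3ccc(NC(=O)CCCCCCC(=O)NO)cc3)nc3[nH]ccc23)cn1` keeps the core and changes one group: methoxy in place of vinyl on a saturated chain carbon, two bonds along the chain from an aromatic nitrogen. Put another way, but-3-en-1-yl gives way to 2-methoxyethyl.

Two measured steps show what placing a chain on that nitrogen has done so far: a 2.2-fold lower number from compound 1 to compound 2 (0.35 log units; beyond the scatter) and a 3.5-fold lower number from compound 1 to compound 3 (0.55 log units; beyond the scatter), both modest. Compound 4 keeps a chain there, so the gain over compound 1 is expected to remain. Among the compounds with values here, the closest precedent is a 1.6-fold lower number from compound 2 to compound 3 (0.20 log units; within the scatter), a swap at the same place that stays within the scatter. Within the data shown here, none of the measured chains contains oxygen, however, so this precedent is imperfect and the range must stay wide. No step beyond the scatter is therefore expected in this assay, only a possible slight drift toward a higher number. The expected change is a 1.2-fold higher number from compound 3 to compound 4 (0.09 log units; within the scatter). For compound 4 the estimated value is 5000 nM, with an expected range from 2500 nM to 10000 nM.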

Compound 4, half-maximal inhibitory concentration: 9400 nM
Compound 4: the middle estimate sits 1.9-fold (0.27 log units) below what was measured, and the stated range covers the measured number.
By their numbers in this assay, from the lowest: compounds 3, 2, 4 and 1 (each within the scatter of the next, the first and the last beyond it).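

In this assay, within the data shown here, methoxy in place of vinyl on a saturated chain carbon, two bonds along the chain from an aromatic nitrogen, gives the only step between two of these chains that lies beyond the scatter, though it is modest (a 2.3-fold higher number from compound 3 to compound 4 (0.36 log units; beyond the scatter)). Against the propyl chain the change is within the scatter (a 1.4-fold higher number from compound 2 to compound 4 (0.16 log units; within the scatter)), and against hydrogen on that nitrogen it is also within the scatter (a 1.5-fold lower number from compound 1 to compound 4 (0.19 log units; within the scatter)), so the 2-methoxyethyl chain, unlike propyl and but-3-en-1-yl, cannot be told apart from hydrogen, which shows that placing a chain here does not by itself secure a measurable gain. Nothing at hand gives a reason for this.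

From the compounds shown here alone, compound 4 brings in an oxygen and loses the double bond in a single change, so it remains open which of the two matters. Also open, going by these compounds, is how this position would respond to a longer chain ending in methoxy, or to a chain ending in an amine or a carboxylic acid.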